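A few compounds are considered here, and "the series" means these few. Any claim that something is new, unique, unknown or untested is made for them only; others in the source may bear on it.

Values so far in a functional assay on HeLa cells (Homo sapiens) for antiproliferative activity, read by MTT assay, with a stated time of 24 h (on this read-out higher numbers stand for weaker inhibition and lower numbers for stronger inhibition), for the series
compound 1 `FC(F)(F)c1ccc(-c2nn(-c3ccccc3)cc2-c2nc3ccccc3[nH]2)cc1` gives 4670 nM
compound 2 `Cc1ccc(-c2nn(-c3ccccc3)cc2-c2nc3ccccc3n2S(=O)(=O)c2ccc(F)cc2)cc1` gives 3670 nM
compound 3 `O=S(=O)(c1ccc(F)cc1)n1c(-c2cn(-c3ccccc3)nc2-c2ccc(F)cc2)nc2ccccc21` gives 2440 nM

Compound 1 stands within the usual scatter of both compound 2 and compound 3, so these values set no order among the three. Compound 4 `O=S(=O)(c1ccccc1)n1c(-c2cn(-c3ccccc3)nc2-c2ccc(C(F)(F)F)cc2)nc2ccccc21` is compound 1 with a single change, phenylsulfonyl in place of hydrogen on an aromatic nitrogen in words phenylsulfonyl in place of hydrogen on an aromatic nitrogen. Going by the values given here, the only measured step, a 1.5-fold lower number from compound 2 to compound 3 (0.18 log units; within the scatter) in size, swaps methyl for fluoro on an aromatic carbon. Among the compounds with values here, it leaves that nitrogen untouched, so it offers no direct read on the new change, and no measured pair isolates that change. The nearest evidence is indirect. Compound 2 at 3670 nM and compound 3 at 2440 nM both carry a fluorinated phenylsulfonyl on that nitrogen, and both stay within the scatter of compound 1 at 4670 nM despite differing from it at another aromatic substituent. No step beyond the scatter is therefore expected in this assay for this change, with a slightly lower number the likelier direction. The estimated step is a 1.6-fold lower number from compound 1 to compound 4 (0.19 log units; within the scatter) and it is expected to stay within the scatter. For compound 4 the estimated value is 3000 nM with an expected range from 1300 nM to 6500 nM as a working figure.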

Compound 4, half-maximal inhibitory concentration: 560 nM
Compound 4: middle estimate off by 5.4-fold (0.73 log units), on the high side; measured number below the stated range.
By their numbers in this assay, from the lowest: compound 4; then compounds 3, 2 and 1 (each within the scatter of the next).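

In this assay, phenylsulfonyl in place of hydrogen on the aromatic nitrogen gives an 8.3-fold lower number from compound 1 to compound 4 (0.92 log units; beyond the scatter), the first single-place read at this position and one that lies beyond the scatter. Going by these compounds alone, the only earlier step, a 1.5-fold lower number from compound 2 to compound 3 (0.18 log units; within the scatter), concerned an aromatic carbon and stayed within the scatter, so this is the first change with a readable direction. With the trifluoromethyl substituent of compound 1 in place, this nitrogen carries the phenylsulfonyl group with a lower number on this read-out, and no measurement at hand bears on the reason.

Whether the step carries over to the methyl and fluoro aromatic substituents of compound 2 and compound 3 stays open, as neither has a partner with hydrogen on that nitrogen among the compounds shown. Also open, on these data alone, is which part of the group matters: a methylsulfonyl, an acetyl or a benzyl group on the same nitrogen would help separate the sulfonyl from the aromatic ring.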